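The source may hold more compounds than are shown below. What is called first, only, known or untested is meant among the compounds shown, and "the series" means these compounds.

Measured in a functional assay on MT4 cells (Homo sapiens) for cytotoxicity; on this read-out higher numbers stand for weaker inhibition and lower numbers for stronger inhibition:
- Compound 1 `Cc1ccc(Sc2cccc(N)c2C#N)cc1`: > 200000 nM, a limit and not a number
- Compound 2 `N#Cc1c(N)cccc1Sc1ccc(Cl)cc1`: 113000 nM

Among the compounds with values here, compound 2 holds the only actual number so far, 113000 nM. Compound 3 `N#Cc1ccc(Sc2cccc(N)c2C#N)cc1` has not been measured and differs from it by cyano in place of chloro on an aromatic carbon, para to a large group. Within the data shown here, the only measured step is chloro in place of methyl on an aromatic carbon. With just an at least 1.7-fold lower number from compound 1 to compound 2 (0.24 log units; that floor lies within the scatter) to go on, no step beyond the scatter is expected in this assay. The step expected is a 1.2-fold higher number from compound 2 to compound 3 (0.06 log units; within the scatter). Compound 3 is estimated at 130000 nM, within an expected range of 60000 nM to 280000 nM.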

Compound 3, half-maximal inhibitory concentration: > 200000 nM
Compound 3 ended at the assay's limit; the forecaster's own chance of this, stated with the estimate: 40%; middle value at least 1.5-fold (0.18 log units) from the limit.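

In this assay, going by these compounds, cyano in place of chloro on this aromatic carbon gives an at least 1.7-fold higher number from compound 2 to compound 3 (0.24 log units; that floor lies within the scatter), so the true size of the step stays unknown and its floor does not separate the two compounds. Compound 3 and compound 1 both give only a limit, and the step between them cannot be read. Of the three groups at this position, only chloro gives an actual number, and the rest of the series sits at a limit: the limit of > 200000 nM in this assay, at which 2 of the 3 values shown sit.

On these data alone, whether a methoxy group, an amine or a carboxylic acid at this position would give a number remains open. So does how such a number would compare with that of compound 2.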